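The source may report more compounds than this note shows. Statements on the series, on what has been measured and on what is new or still open speak of the compounds shown alone.

Measured so far in a functional assay on PC-3 cells (Homo sapiens) for antiproliferative activity, read by MTT assay, tested at 1 uM; a higher number here means a stronger effect of the compound at the concentration tested, a lower number a weaker effect:

- compound 1, `COc1cc(C(=O)N/N=C/c2ccc(F)c(F)c2)cc(OC)c1OC`, gives 35.1%
- compound 2, `COc1cc(C(=O)N/N=C/c2cccc(F)c2)cc(OC)c1OC`, gives 53.5%

Compound 2 stands highest of the two numbers; its nearest neighbour is compound 1, and the step there is a number 18.4 percentage points higher from compound 1 to compound 2 (beyond the scatter), hydrogen in place of fluoro on an aromatic carbon.

The next compound, compound 3, `COc1cc(C(=O)N/N=C/c2c(Cl)cccc2Cl)cc(OC)c1OC`, differs from compound 2 as follows: 2,6-dichlorophenyl in place of 3-fluorophenyl on a carbon with a double bond to nitrogen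

For the measured compounds named here, only one measured step exists in this assay, and it bears on the change only loosely: it shows that removing a fluoro from the aryl ring on the carbon with a double bond to nitrogen moved the number by a number 18.4 percentage points higher from compound 1 to compound 2 (beyond the scatter), a modest step beyond the scatter. Going by the values given here, no measured pair shows 2,6-dichlorophenyl in place of 3-fluorophenyl, nor any chloro on that ring. The change is therefore not covered by the measured steps, and any expectation must carry a wide range. The working expectation for compound 3 is a step of a number 13.5 percentage points lower from compound 2 to compound 3 (beyond the scatter), downward, of modest size. Compound 3 is thus estimated at 40%, with a range from 15% to 65%.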

Compound 3, a percentage reported as inhibition, at one concentration (the size of the read-out at that concentration, not a potency): 43%
Estimate against measurement, compound 3: 3 percentage points below; low and high end bracket the measured number.
By their numbers in this assay, from the lowest: compounds 1 and 3 (each within the scatter of the next); then compound 2.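

In this assay, for the compounds shown here, 2,6-dichlorophenyl in place of 3-fluorophenyl on the carbon with a double bond to nitrogen gives a number 10.5 percentage points lower from compound 2 to compound 3 (beyond the scatter) and provides the first reading of chloro on this ring, showing that the read-out is not lost with this group. Against 3,4-difluorophenyl, the same group gives a number 7.9 percentage points higher from compound 1 to compound 3 (within the scatter) and so does not separate the two dihalogenated rings, while 3-fluorophenyl stays apart from both, with each of its steps printed beyond the scatter. Nothing at hand accounts for these steps.

Among the compounds shown, the number of halogens and their places change together, so it remains open whether either one alone governs the read-out, a question that 2,6-difluorophenyl or a single chloro on the ring would help to separate. Also open, on these data alone, is how the ring behaves with a non-halogen group such as methoxy or dimethylamino, and whether a stronger or weaker effect seen at one concentration in this assay would hold at other concentrations.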